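The source may hold more compounds than are shown below. What is called first, only, known or untested is meant among the compounds shown, and "the series" means these compounds.

Measured compounds:
compound 1 `COc1ccc(C(CCCCCN2CCc3cc(OC)c(OC)cc3C2)Sc2ccc(C)cc2)cc1OC`; in a functional assay on S1B1-20 cells (Homo sapiens) (on this read-out lower numbers stand for stronger inhibition and higher numbers for weaker inhibition), compound 1 gives 330 nM
compound 2 `COc1ccc(C(CCCCCN2CCc3cc(OC)c(OC)cc3C2)SC2CCCCC2)cc1OC`; in this assay compound 2 gives 730 nM
compound 3 `COc1ccc(C(CCCCCN2CCc3cc(OC)c(OC)cc3C2)SCc2ccccc2)cc1OC`; in this assay compound 3 gives 1980 nM

Of the three compounds measured, compound 3 stands at the highest number, and both of its neighbours lie beyond the scatter: the change is a 6.0-fold higher number from compound 1 to compound 3 (0.78 log units; beyond the scatter), and the change is a 2.7-fold higher number from compound 2 to compound 3 (0.43 log units; beyond the scatter). Compound 4 `COc1ccc(C(CCCCCN2CCc3cc(OC)c(OC)cc3C2)SC(C)(C)C)cc1OC` is not yet measured. It differs from compound 3 in one place: tert-butyl in place of benzyl on a sulfur.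

Within the data shown here, no measured step covers tert-butyl itself. Among the measured compounds shown here, the steps that bear on the question are those among the groups on the same sulfur: a 2.2-fold higher number from compound 1 to compound 2 (0.34 log units; beyond the scatter) and a 2.7-fold higher number from compound 2 to compound 3 (0.43 log units; beyond the scatter). Cyclohexyl, which like tert-butyl carries no ring of aromatic carbon and sits directly on the sulfur, gave a lower number than benzyl. On that ground a modest improvement over compound 3 is expected in this assay, toward the level of compound 2 rather than that of compound 1, and the expected step is a 2.2-fold lower number from compound 3 to compound 4 (0.34 log units; beyond the scatter). For compound 4 the estimate in this assay is 900 nM, with a range from 350 nM to 2500 nM.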

Compound 4, half-maximal inhibitory concentration: 3580 nM
Compound 4: the middle estimate sits 4.0-fold (0.60 log units) below what was measured; measured number outside the range, above it.
By their numbers in this assay, from the lowest: compound 1; then compound 2; then compounds 3 and 4 (each within the scatter of the next).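

In this assay, tert-butyl in place of benzyl on the sulfur gives a 1.8-fold higher number from compound 3 to compound 4 (0.26 log units; within the scatter) and so does not separate the two groups, even though tert-butyl has no ring and the benzyl group carries an aromatic one. The absence of an aromatic ring is therefore no sufficient guide at this position: the two groups without one do not read alike, since tert-butyl in place of cyclohexyl gives a 4.9-fold higher number from compound 2 to compound 4 (0.69 log units; beyond the scatter) and thus separates the branched open group from the saturated ring. The widest step among these four compounds is an 11-fold higher number from compound 1 to compound 4 (1.04 log units; beyond the scatter) and it confirms that the 4-methylphenyl group directly on the sulfur gives the lowest number of the set, with all three of its steps beyond the scatter.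

On these data alone, how an unsubstituted phenyl, a 4-methoxyphenyl or an isopropyl group on the same sulfur would read remains open, so the contributions of the methyl group, of branching and of ring size cannot yet be separated. Nothing presented here offers an explanation for the differences among these sulfur substituents.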